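The compounds below may be only part of what the source reports. "The series", "measured", "known", "first", "only" and "open" are said of these compounds alone.

Compound 1 `Cc1nn(-c2nc(-c3ccc(Cl)c(Cl)c3)c(SC(C)C)s2)c(C(=O)O)c1-c1cncnc1`: 22000 nM
Compound 2 `COc1ccc(-c2c(C)nn(-c3nc(-c4ccc(Cl)c(Cl)c4)c(SC(C)C)s3)c2C(=O)O)cc1`: 2100 nM
Compound 3 `Cc1cc(Cl)cc(-c2c(C)nn(-c3nc(-c4ccc(Cl)c(Cl)c4)c(SC(C)C)s3)c2C(=O)O)c1`: 663 nM

These three compounds share one core and differ only in the aromatic group attached to it. In a functional assay on BJAB cells (Homo sapiens) for antiproliferative activity, with a stated time of 4 days (on this read-out higher numbers stand for an effect only at larger amounts of compound and lower numbers for an effect already at smaller amounts), compound 1 gives 22000 nM, compound 2 gives 2100 nM and compound 3 gives 663 nM. Compound 3 thus stands lowest of the three, and both gaps to it lie beyond the scatter: the step of a 3.2-fold lower number from compound 2 to compound 3 (0.50 log units; beyond the scatter) is modest, the step of a 33-fold lower number from compound 1 to compound 3 (1.52 log units; beyond the scatter) is large.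

Compound 4 `Cc1nn(-c2nc(-c3ccc(Cl)c(Cl)c3)c(SC(C)C)s2)c(C(=O)O)c1-c1cnccn1` has not yet been measured. It differs from compound 3 in one place: pyrazin-2-yl in place of 3-chloro-5-methylphenyl on an aromatic carbon. Going by the values given here, two measured steps bear on this change. Going from a six-membered ring with two nitrogens to a carbon-only ring gave a 10-fold lower number from compound 1 to compound 2 (1.02 log units; beyond the scatter) and a 33-fold lower number from compound 1 to compound 3 (1.52 log units; beyond the scatter). Compound 4 goes the opposite way, from a carbon-only ring back to a six-membered ring with two nitrogens, so a large step to higher numbers is expected, close to the value of compound 1. The expected step is a 23-fold higher number from compound 3 to compound 4 (1.35 log units; beyond the scatter). Compound 4 is therefore estimated at 15000 nM in this assay, with a range from 4000 nM to 50000 nM.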

Compound 4, half-maximal effective concentration: 14000 nM
The estimate for compound 4 lay 1.1-fold (0.03 log units) above the measured number; measured number inside the range.
By their numbers in this assay, from the lowest: compound 3; then compound 2; then compounds 4 and 1 (each within the scatter of the next).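

In this assay, moving from the pyrimidin-5-yl ring to the pyrazin-2-yl ring gives a 1.6-fold lower number from compound 1 to compound 4 (0.20 log units; within the scatter), so these two rings, each with two nitrogens, cannot be told apart at this position. Both carbon-only rings stand clearly apart from the pyrazin-2-yl ring, with a 21-fold higher number from compound 3 to compound 4 (1.32 log units; beyond the scatter) and a 6.7-fold higher number from compound 2 to compound 4 (0.82 log units; beyond the scatter), so the high numbers now appear with two different nitrogen-containing rings rather than with a single one. Nothing measured here explains this gap.

The compounds shown leave open whether a ring with one nitrogen, such as a pyridinyl group, would sit with the carbon-only rings or with the two-nitrogen rings. Going by these compounds, it also remains open how a phenyl ring carrying an amine would compare with the 3-chloro-5-methylphenyl group.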